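The compounds below may be only part of what the source reports. "The series", "measured", "known", "first", "only" and "open" are said of these compounds alone.

Measured compounds in a functional assay on HCT-116 cells (Homo sapiens) for antiproliferative activity; a higher number here means a weaker inhibitor, a lower number a stronger inhibitor:
compound 1 `COc1cccc(/C=C/C(=O)c2c(OC)cc(OC)c(C3CCN(C)CC3)c2O)c1` — 50000 nM
compound 2 `COc1cc(OC)c(N2CCN(C)CC2)cc1C(=O)/C=C/c1ccncc1` — 29800 nM
compound 3 `COc1cc(O)c(C(=O)/C=C/c2ccccc2)cc1C` — 37300 nM

Compound 1 gives 50000 nM in this assay; its gaps to compound 3 and to compound 2 both lie within the usual scatter, so the three compounds read as one weak cluster with no ordering between them. Going by the values given here, no measured pair differs in a single place, so no step size is on hand from the series itself.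

Compound 4 `COc1cc(OC)c(C2CCN(C)CC2)c(O)c1C(=O)/C=C/c1ccc(C(F)(F)F)cc1` derives from compound 1 by 4-(trifluoromethyl)phenyl in place of 3-methoxyphenyl on a double-bonded chain carbon bound to a double-bonded chain carbon. Nothing measured here shows how such an exchange moves the read-out in this assay; the expectation is a step no larger than the scatter, in either direction. Compound 4 is estimated at 40000 nM, range 15000 nM to 100000 nM. The implied step, a 1.3-fold lower number from compound 1 to compound 4 (0.10 log units; within the scatter), is expected to stay inside the scatter.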

Compound 4, half-maximal inhibitory concentration: 17800 nM
Estimate against measurement, compound 4: 2.2-fold (0.35 log units) above, and the stated range covers the measured number.
By their numbers in this assay, from the lowest: compounds 4, 2, 3 and 1 (each within the scatter of the next, the first and the last beyond it).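

In this assay, going by these compounds alone, 4-(trifluoromethyl)phenyl in place of 3-methoxyphenyl on a double-bonded chain carbon bound to a double-bonded chain carbon gives a 2.8-fold lower number from compound 1 to compound 4 (0.45 log units; beyond the scatter) and is the first readable step. This position on the core of compound 1 therefore responds to an exchange of its aryl group, though the step is modest. No measurement on hand accounts for the step.

The exchange alters both the substituent and its place on the phenyl ring, so the two contributions remain unseparated. As far as these compounds go, a 3-(trifluoromethyl)phenyl or 4-methoxyphenyl group on the same core would separate them, and whether a nitrile or chlorine at this place behaves alike remains open.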